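Replacing naphthalen-2-yl with 4-phenylphenyl: working notes

A few compounds are considered here, and "the series" means these few. Any claim that something is new, unique, unknown or untested is made for them only; others in the source may bear on it.

Measured so far in a functional assay on Jurkat cells (Homo sapiens) (a higher number here means a weaker inhibitor, a lower number a stronger inhibitor), are these compounds:
- compound 1 `CC(C)[C@H](NC(=O)COc1cccc2ccccc12)C(=O)N[C@@H](CC(=O)O)C(=O)COc1ccccc1` gives 14000 nM as a number
- compound 2 `CC(C)[C@H](NC(=O)COc1cccc2ccccc12)C(=O)N[C@@H](CC(=O)O)C(=O)COc1ccc2ccccc2c1` gives > 100000 nM as a limit

Compound 2 sits at > 100000 nM in this assay and that is a limit of the assay, not a number. Compound 3 `CC(C)[C@H](NC(=O)COc1cccc2ccccc12)C(=O)N[C@@H](CC(=O)O)C(=O)COc1ccc(-c2ccccc2)cc1` carries 4-phenylphenyl in place of naphthalen-2-yl on an oxygen on a saturated carbon and is still unmeasured. Going by the values given here, one measured step bears on this place: an at least 7.1-fold higher number from compound 1 to compound 2 (0.85 log units; beyond the scatter) and it lies beyond the scatter. Among the compounds with values here, no measured step starts from naphthalen-2-yl, so the comparison stays indirect. Compound 3 is expected to remain a weak inhibitor like compound 2 because an at least 7.1-fold higher number from compound 1 to compound 2 (0.85 log units; beyond the scatter) gives no sign of a gain from leaving phenyl. The estimated size is a number no higher from compound 2 to compound 3 (the limit leaves the size open) and no step beyond the scatter is expected. For compound 3 the estimate is 100000 nM with an expected range of 30000 nM to 300000 nM and a reading at the assay limit is likely.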

Compound 3, half-maximal inhibitory concentration: 87900 nM
Estimate against measurement, compound 3: 1.1-fold (0.06 log units) above; measured number inside the range.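

In this assay, at the oxygen on a saturated carbon, phenyl added to the phenyl of compound 1 brings a 6.3-fold higher number from compound 1 to compound 3 (0.80 log units; beyond the scatter), so the loss seen with naphthalen-2-yl is not confined to that one group. Between the two larger groups, the listed change is an at least 1.1-fold lower number from compound 2 to compound 3 (0.05 log units; that floor lies within the scatter), which allows no order to be stated between them. On these data alone, compound 2 remains at a limit of the assay, not a number, and the true size of that step stays open: the limit of > 100000 nM in this assay, at which 1 of the 3 values shown sits.

The three groups shown on this oxygen are all aromatic and made of carbon only, so it stays open whether a single fluorine or methoxy group on the phenyl of compound 1 would hold or improve on the reading of compound 1, 14000 nM. Also open, as far as these compounds go, is how a pyridine ring or an aminophenyl group would read at this place.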